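The source may hold more compounds than are shown below. What is called first, only, known or untested is meant among the compounds shown, and "the series" means these compounds.

Working notes on the series. Compound 1 `CCC1(CCCCN2CCN(c3cccc(Cl)c3)CC2)C(=O)Nc2ccccc21` gives 0.41 nM in an assay on CHO cells for displacement of a labelled ligand from 5-hydroxytryptamine receptor 7 (Homo sapiens) (on this read-out higher numbers stand for weaker inhibition and lower numbers for stronger inhibition), the lowest of the three numbers measured; compound 2 `CCC1(CCCCN2CCN(c3ccccc3)CC2)C(=O)Nc2ccccc21` gives 2.07 nM and compound 3 `CCC1(CCCCN2CCN(c3cccc(OC)c3)CC2)C(=O)Nc2ccccc21` gives 2.55 nM. The steps seen so far are a 5.0-fold higher number from compound 1 to compound 2 (0.70 log units; beyond the scatter), a 6.2-fold higher number from compound 1 to compound 3 (0.79 log units; beyond the scatter) and a 1.2-fold higher number from compound 2 to compound 3 (0.09 log units; within the scatter), all at the aromatic carbon. Compound 4 `O=C1Nc2ccccc2C1CCCCN1CCN(c2cccc(Cl)c2)CC1` differs from compound 1 by hydrogen in place of ethyl on a saturated ring carbon. Among the measured compounds shown here, no measured step touches the saturated ring carbon, so none bears directly on this change; the ethyl-free compounds have no precedent here. A modest weakening is therefore expected for compound 4, without a firm basis, amounting to a 3.7-fold higher number from compound 1 to compound 4 (0.56 log units; beyond the scatter). The estimate for compound 4 in this assay is 1.5 nM, within 0.4 nM to 6 nM.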

Compound 4, inhibition constant: 0.49 nM
Estimate against measurement, compound 4: 3.1-fold (0.49 log units) above, and the stated range covers the measured number.
By their numbers in this assay, from the lowest: compounds 1 and 4 (each within the scatter of the next); then compounds 2 and 3 (each within the scatter of the next).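

In this assay, hydrogen in place of ethyl on the saturated ring carbon gives a 1.2-fold higher number from compound 1 to compound 4 (0.08 log units; within the scatter), so with the chloro group on the aromatic carbon, ethyl is not required for a number this low. This first step at the position stays within the scatter, whereas both steps from compound 1 at the aromatic carbon go beyond it. No measured evidence explains this result. From the compounds shown here alone, it remains open whether butyl, hydroxyl or an amine on the saturated ring carbon would keep the number in this range. Going by these compounds, whether removing ethyl behaves alike with hydrogen or methoxy on the aromatic carbon also remains open.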